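Changing the aryl group on the carbonyl carbon

The source may hold more compounds than are shown below. What is called first, only, known or untested is meant among the compounds shown, and "the series" means these compounds.

In an in vitro ADME assay on microsomes from liver (Homo sapiens) for metabolic stability (a lower number here means slower removal, a higher number faster removal of the compound), compound 1 `CC(C)NC(=O)[C@H]1CC[C@@H](n2/c(=N/C(=O)c3ccc(C#N)c(F)c3)[nH]c3ccc(CN4CCC(C(C)(C)O)CC4)cc32)CC1` gives 132 mL.min-1.g-1. This lies within the scatter of compound 3 `CC(C)NC(=O)[C@H]1CC[C@@H](n2/c(=N/C(=O)c3ccc(F)cc3)[nH]c3ccc(CN4CC(C(C)(C)O)C4)cc32)CC1` at 105 mL.min-1.g-1. Compound 2 `CC(C)NC(=O)[C@H]1CC[C@@H](n2/c(=N/C(=O)c3ccc(F)cc3)[nH]c3ccc(CN4CCC[C@H]4C(C)(C)O)cc32)CC1` gives 569 mL.min-1.g-1. Its gap to each of the other two compounds is larger than the scatter. Compound 4 `CC(C)NC(=O)[C@H]1CC[C@@H](n2/c(=N/C(=O)c3cc(F)cc(Cl)c3)[nH]c3ccc(CN4CCC(C(C)(C)O)CC4)cc32)CC1` differs from compound 1 in one place: 3-chloro-5-fluorophenyl in place of 4-cyano-3-fluorophenyl on a carbonyl carbon. Among the compounds with values here, the only measured step, a 5.4-fold lower number from compound 2 to compound 3 (0.73 log units; beyond the scatter), exchanges the hydroxy-bearing azetidinyl and pyrrolidinyl groups and leaves the group on the carbonyl carbon untouched. Within the data shown here, no measured step therefore bears directly on this change, and its size gives only a loose guide. The expected step, a 1.3-fold higher number from compound 1 to compound 4 (0.11 log units; within the scatter), is a small rise estimated to stay within the scatter. Compound 4 is expected at 170 mL.min-1.g-1, with a range of 85 mL.min-1.g-1 to 340 mL.min-1.g-1.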

Compound 4, intrinsic clearance in microsomes: 83 mL.min-1.g-1
Compound 4: middle estimate off by 2.0-fold (0.31 log units), on the high side; measured number below the stated range.
By their numbers in this assay, from the lowest: compounds 4, 3 and 1 (each within the scatter of the next); then compound 2.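

Working on a carbonyl carbon, 3-chloro-5-fluorophenyl in place of 4-cyano-3-fluorophenyl is the first measured exchange at this position, and in this assay it gives a 1.6-fold lower number from compound 1 to compound 4 (0.20 log units; within the scatter) on the unchanged core of compound 1. In this pair, then, the nitrile can leave and chlorine can enter without the number moving beyond the scatter. Nothing available explains why the two aryl groups read alike.

As far as these compounds go, this rests on one pair, so whether it holds with the azetidinyl and pyrrolidinyl groups of compound 3 and compound 2 stays open. From the compounds shown here alone, how a pyridyl or 4-methoxyphenyl group on this carbonyl carbon would read is also open.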